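The source may hold more compounds than are shown below. What is called first, only, known or untested is meant among the compounds shown, and "the series" means these compounds.

Compound 1 `COc1ccccc1NC(=S)N/N=C/c1ccc2ccccc2n1`: in a functional assay on HT-29 cells (Homo sapiens) for antiproliferative activity, read by sulforhodamine B assay, with a stated time of 72 h (on this read-out lower numbers stand for stronger inhibition and higher numbers for weaker inhibition), compound 1 gives > 100000 nM, which is a limit of the assay and not a number.
Compound 2 `FC(F)(F)c1ccccc1NC(=S)N/N=C/c1ccc2ccccc2n1`: in this assay compound 2 gives 18100 nM.

Of these two, compound 2 holds the only number shown; the other value is a limit (the limit of > 100000 nM in this assay, at which 1 of the 2 values shown sits). The step to compound 3 `Fc1ccccc1NC(=S)N/N=C/c1ccc2ccccc2n1` changes one group on the aromatic ring: fluoro in place of trifluoromethyl on an aromatic carbon. Within the data shown here, only one measured step bears on it, an at least 5.5-fold lower number from compound 1 to compound 2 (0.74 log units; beyond the scatter), and that step shows the trifluoromethyl compound as the sole one yielding a number rather than a limit. With trifluoromethyl now giving way to the single fluoro, compound 3 is expected to drift back toward the weaker side, with a fair chance of again returning only a limit, so the estimated step is a 2.5-fold higher number from compound 2 to compound 3 (0.40 log units; beyond the scatter). Compound 3 is therefore expected to give about 45000 nM in this assay, within a range of 15000 nM to 100000 nM.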

Compound 3, half-maximal inhibitory concentration: > 100000 nM
Compound 3 ended at the assay's limit (the forecaster's own chance of this, stated with the estimate: 35%); middle value at least 2.2-fold (0.34 log units) away from the limit.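

Replacing trifluoromethyl with fluoro on this aromatic carbon, ortho to a large group, gives an at least 5.5-fold higher number from compound 2 to compound 3 (0.74 log units; beyond the scatter) in this assay. Among these compounds, the earlier pair showed only that trifluoromethyl gave a number where methoxy did not; this change shows that a fluorine-bearing group at this position is not enough in itself, since the single fluoro yields no number. The step from compound 1 to compound 3 cannot be read, and compound 2 remains the only compound with a number: the limit of > 100000 nM in this assay, at which 2 of the 3 values shown sit.

The compounds shown leave open whether a readable number here is particular to trifluoromethyl or would also appear with a chloro, a methyl or a nitrile on the same carbon. They also leave open how an amine or a carboxylic acid would read there.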